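Amine-ring substituent variation: from compound 3 to compound 4

The source may hold more compounds than are shown below. What is called first, only, known or untested is meant among the compounds shown, and "the series" means these compounds.

All four compounds share one core and differ only in the group on an amine nitrogen in a ring. Compound 1 `CCCn1c(=O)[nH]c2nc(-c3ccc(S(=O)(=O)N4CCN(c5cccc(Br)c5)CC4)cc3)[nH]c2c1=O` gives 0.234 nM in an assay on CHO cells for displacement of a labelled ligand from adenosine receptor A2b (Homo sapiens), read by scintillation counting, with a stated time of 75 min, in the presence of a further agent that is not named here; a higher number here means a weaker inhibitor, a lower number a stronger inhibitor. Compound 2 `CCCn1c(=O)[nH]c2nc(-c3ccc(S(=O)(=O)N4CCN(Cc5ccc(Br)cc5)CC4)cc3)[nH]c2c1=O` gives 0.153 nM, and compound 3 `CCCn1c(=O)[nH]c2nc(-c3ccc(S(=O)(=O)N4CCN(c5ccc(I)cc5)CC4)cc3)[nH]c2c1=O` gives 0.159 nM. Compound 3 sits within the scatter of both neighbours: a 1.5-fold lower number from compound 1 to compound 3 (0.17 log units; within the scatter) and a 1.0-fold higher number from compound 2 to compound 3 (0.02 log units; within the scatter). Compound 4 `CCCn1c(=O)[nH]c2nc(-c3ccc(S(=O)(=O)N4CCN(Cc5cccc(Br)c5)CC4)cc3)[nH]c2c1=O` carries 3-bromobenzyl in place of 4-iodophenyl on an amine nitrogen in a ring. Every measured step bears on this change, the direct-to-methylene-linked swap a 1.5-fold lower number from compound 1 to compound 2 (0.18 log units; within the scatter) as much as the halogen swaps, and all three lie within the scatter. No shift beyond the scatter is therefore expected, and the step of a 1.1-fold higher number from compound 3 to compound 4 (0.05 log units; within the scatter) is the estimate. Compound 4 is expected at 0.18 nM, with a range of 0.08 nM to 0.4 nM.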

Compound 4, inhibition constant: 0.148 nM
Compound 4: middle estimate off by 1.2-fold (0.09 log units), on the high side, within the range that was stated.
By their numbers in this assay, from the lowest: compounds 4, 2, 3 and 1 (each within the scatter of the next).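

Among the compounds shown here, compound 4 gives two single-change comparisons that the earlier compounds lacked. Moving the bromine from 4-bromophenyl to 3-bromophenyl on the saturated chain carbon stays within the scatter (a 1.0-fold lower number from compound 2 to compound 4 (0.01 log units; within the scatter)), as does placing 3-bromobenzyl in place of 3-bromophenyl on the amine nitrogen (a 1.6-fold lower number from compound 1 to compound 4 (0.20 log units; within the scatter)). The exchange of 4-iodophenyl for 3-bromobenzyl also stays within the scatter (a 1.1-fold lower number from compound 3 to compound 4 (0.03 log units; within the scatter)), and no available evidence accounts for these results.

As far as these compounds go, whether this position tolerates a group without an aromatic ring, such as an amine, a carboxylic acid or a longer chain, remains open.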